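A few compounds are considered here, and "the series" means these few. Any claim that something is new, unique, unknown or untested is made for them only; others in the source may bear on it.

Measured so far in a functional assay on HO8910 cells (Homo sapiens) for inhibition, read by MTT assay, with a stated time of 24 h, tested at 100 ug/mL; a lower number here means less inhibition of growth, a higher number more inhibition of growth at the concentration tested:
compound 1, `O=C(CCCCC1CCSS1)Nc1ccccn1`, gives 51.9%;
compound 2, `O=C(CCCCC1CCSS1)Nc1ccc(Cl)cn1`, gives 68.6%;
compound 3, `O=C(CCCCC(CCSC(=O)c1ccccc1)SC(=O)c1ccccc1)Nc1ccccc1`, is reported only as "not active" (no number reported), with no number.

Compound 2 differs from compound 1 by one change, (chloro in place of hydrogen on an aromatic carbon), and that change gave a number 16.7 percentage points higher from compound 1 to compound 2 (beyond the scatter). Compound 4, `O=C(CCCCC(CCSC(=O)c1ccccc1)SC(=O)c1ccccc1)Nc1ccccc1Cl`, has not yet been measured. It differs from compound 3 by chloro in place of hydrogen on an aromatic carbon. For the measured compounds named here, this is the same kind of change as the one from compound 1 to compound 2, but not the same: in compound 2 the chloro sits on a six-membered aromatic ring with one nitrogen, two atoms from the ring nitrogen and para to a large group, while in compound 4 it sits on a six-membered aromatic ring of carbon only, ortho to a large group. The difference between the core of compound 1 and the core of compound 3 is not broken down here. Since compound 3 gave no number, the step from compound 3 to compound 4 cannot be measured against the earlier one; the earlier step was modest, and the same kind of change is expected to move the result by about as much. Compound 4 is therefore expected to give about 15%, in a range from 0% to 40%.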

Compound 4, percent growth inhibition at one concentration: "not active" (no number reported)
The entry for compound 4 holds no number, so the estimate cannot be set against anything.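

In this assay, for the compounds shown here, compound 3 and compound 4 are both reported only as "not active", without a number, so no step between them can be read. These compounds leave open whether chloro in place of hydrogen changes growth inhibition at all on their shared core. Nothing available here helps explain this result.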